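A few compounds are considered here, and "the series" means these few. Any claim that something is new, unique, unknown or untested is made for them only; others in the source may bear on it.

Compound 1 `COc1ccc(Cn2cc(CNC(=O)c3cn(-c4ccccc4)nc3-c3ccccc3)nn2)cc1` gives 10200 nM in a functional assay on MIA PaCa-2 cells (Homo sapiens) for antiproliferative activity, read by sulforhodamine B assay, with a stated time of 48 h; a higher number here means a weaker inhibitor of growth, a lower number a stronger inhibitor of growth. Compound 2 `COc1ccc(Cn2cc(CNC(=O)c3cn(-c4ccccc4)nc3-c3ccccc3)nn2)cc1OC` carries methoxy in place of hydrogen on an aromatic carbon and gives 8200 nM in this assay, a step of a 1.2-fold lower number from compound 1 to compound 2 (0.09 log units; within the scatter). Compound 3 `COc1ccc(Cn2cc(CNC(=O)c3cn(-c4ccccc4)nc3-c3ccc(Cl)cc3)nn2)cc1` gives 290 nM in this assay, a step of a 35-fold lower number from compound 1 to compound 3 (1.55 log units; beyond the scatter). Compound 4 `COc1ccc(Cn2cc(CNC(=O)c3cn(-c4ccccc4)nc3-c3ccc(Cl)cc3)nn2)cc1OC` has not been measured in this assay. It differs from compound 3 by methoxy in place of hydrogen on an aromatic carbon, the same change as that from compound 1 to compound 2, made on a core that differs from the core of compound 1 by chloro in place of hydrogen on an aromatic carbon. For compound 4 the expected step is a 1.2-fold lower number from compound 3 to compound 4 (0.06 log units; within the scatter), resting on the earlier step of a 1.2-fold lower number from compound 1 to compound 2 (0.09 log units; within the scatter), which stayed within the scatter. Compound 4 is therefore estimated at 250 nM in this assay, expected between 110 nM and 600 nM.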

Compound 4, concentration for 50% growth inhibition: 9400 nM
Beside the measured number, compound 4's estimate is 38-fold (1.58 log units) below it; measured number above the stated range.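

In this assay, methoxy in place of hydrogen on the core carrying chloro gives a 32-fold higher number from compound 3 to compound 4 (1.51 log units; beyond the scatter), so this change did not carry over from the core of compound 1: the same change on two cores in this assay, a 1.2-fold lower number (0.09 log units; within the scatter) from compound 1 to compound 2 and a 32-fold higher number (1.51 log units; beyond the scatter) from compound 3 to compound 4, 40-fold (1.61 log units) apart, beyond the scatter of two such steps

Seen from the other side, chloro in place of hydrogen gives a 1.1-fold higher number from compound 2 to compound 4 (0.06 log units; within the scatter), so the two changes do not add: the same change on two cores in this assay, a 35-fold lower number (1.55 log units; beyond the scatter) from compound 1 to compound 3 and a 1.1-fold higher number (0.06 log units; within the scatter) from compound 2 to compound 4, 40-fold (1.61 log units) apart, beyond the scatter of two such steps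

This shows that the effect of each change depended on the other in these four compounds, but it rests on one pair of cores and does not show why.

As far as these compounds go, whether hydroxy or ethoxy in place of the entering methoxy, or fluoro or bromo in place of the chloro, would show the same dependence remains open.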